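The compounds below may be only part of what the source reports. "The series", "measured", "known", "first", "only" and "open" are said of these compounds alone.

Working notes on the series.

In a functional assay on MIA PaCa-2 cells (Homo sapiens) for antiproliferative activity, read by sulforhodamine B assay, with a stated time of 48 h (a lower number here means a stronger inhibitor of growth, a higher number a weaker inhibitor of growth), compound 1, `COc1cc(Cn2cc(CNC(=O)c3cn(-c4ccccc4)nc3-c3ccc(Cl)cc3)nn2)cc(OC)c1`, gives 340 nM. Compound 2, `COc1ccc(-c2nn(-c3ccccc3)cc2C(=O)NCc2cn(Cc3ccc(C(F)(F)F)cc3)nn2)cc1`, reaches only (the limit of > 100000 nM in this assay, at which 1 of the 3 values shown sits), a limit and not a number, recorded for compound 2 as > 100000 nM. Going by the values given here, compound 3, `COc1ccc(-c2nn(-c3ccccc3)cc2C(=O)NCc2cn(Cc3ccc(OC)c(OC)c3)nn2)cc1`, gives 16300 nM in this assay, the highest of the two numbers known so far; compound 1 sits well below it, and the two differ in the shared core as well as in the benzyl group, so no single step joins them. Among the compounds with values here, the one measured step, an at least 6.1-fold lower number from compound 2 to compound 3 (0.78 log units; beyond the scatter), shows that exchanging the group on the saturated chain carbon bound to an aromatic nitrogen moves this assay by a clear margin.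

Compound 4, `COc1ccc(-c2nn(-c3ccccc3)cc2C(=O)NCc2cn(Cc3cc(OC)cc(OC)c3)nn2)cc1`, is the next step from compound 3: 3,5-dimethoxyphenyl in place of 3,4-dimethoxyphenyl on a saturated chain carbon bound to an aromatic nitrogen. Within the data shown here, only the step from compound 2 to compound 3 bears on it directly, and it was at least modest; compound 1 carries the same 3,5-dimethoxybenzyl group on a different core and gives a low number. For compound 4 the number in this assay is therefore expected to be lower than for compound 3, by a step of a 3.3-fold lower number from compound 3 to compound 4 (0.51 log units; beyond the scatter), with the estimate 5000 nM in a range from 1500 nM to 16000 nM.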

Compound 4, concentration for 50% growth inhibition: 5800 nM
Beside the measured number, compound 4's estimate is 1.2-fold (0.06 log units) below it; low and high end bracket the measured number.
By their numbers in this assay, from the lowest: compound 1; then compound 4; then compound 3. At a limit, above all of these: compound 2.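

Moving a single methoxy group, with the atoms otherwise unchanged, is enough to shift this assay, with a 2.8-fold lower number from compound 3 to compound 4 (0.45 log units; beyond the scatter), so on a saturated chain carbon bound to an aromatic nitrogen the arrangement of the two methoxy groups matters as well as their presence, and the 3,5-dimethoxyphenyl group also gives an at least 17-fold lower number from compound 2 to compound 4 (1.23 log units; beyond the scatter) against the 4-(trifluoromethyl)phenyl group. The value for compound 2 is a limit and not a number, so that large step has only a lower bound: the limit of > 100000 nM in this assay, at which 1 of the 4 values shown sits. With the 3,5-dimethoxyphenyl group held constant, methoxy in place of chloro on an aromatic carbon gives a 17-fold higher number from compound 1 to compound 4 (1.23 log units; beyond the scatter), so this group alone does not secure the low number of compound 1, and the change at the other end of the molecule weighs heavily.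

On these data alone, it remains open whether the step from 3,4-dimethoxyphenyl to 3,5-dimethoxyphenyl keeps its direction and size when chloro stands on that aromatic carbon. Also open, as far as these compounds go, is what bromo or methyl in place of chloro on that carbon, or 3,4,5-trimethoxyphenyl in place of 3,5-dimethoxyphenyl on the saturated chain carbon, would give.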